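Shortening the ketone chain in a glutamate receptor modulator series

A few compounds are considered here, and "the series" means these few. Any claim that something is new, unique, unknown or untested is made for them only; others in the source may bear on it.

Compound 2 `CCC(=O)c1ccc(OCCCCOc2ccc(F)c(C(=O)O)c2)c(C)c1O` stands second of the three compounds measured in an assay on HEK293 cells for positive allosteric modulation of metabotropic glutamate receptor 2 (Rattus norvegicus), read by thallium flux, with a stated time of 2.5 min; a higher number here means a larger maximal response, a lower number a smaller maximal response: compound 2 gives 66.6%, while compound 1 `Cc1c(OCCCCOc2ccc(C(=O)O)cc2)ccc(C(=O)CC(C)C)c1O` gives 88% and compound 3 `Cc1c(OCCCCOc2ccc(C(=O)O)cc2)ccc(C(=O)CC(C)C)c1C` gives 19%. Among the compounds with values here, the only single-point step measured, a number 69 percentage points lower from compound 1 to compound 3 (beyond the scatter), concerns the hydroxy group on the aromatic ring and does not bear on the change considered here. Compound 4 `CC(=O)c1ccc(OCCCCOc2ccc(F)c(C(=O)O)c2)c(C)c1O` differs from compound 2 by hydrogen in place of methyl on a saturated chain carbon bound to a carbonyl carbon, so that propanoyl becomes acetyl. Within the data shown here, no measured step tests such a shortening of the chain, so the expected step of a number 6.6 percentage points lower from compound 2 to compound 4 (within the scatter) is taken to stay roughly within the scatter, with a slight lean downward. Compound 4 is therefore estimated at 60%, with a range from 40% to 80%.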

Compound 4, largest response reached (reported as percent of maximum), in percent of the reference or control that the assay uses: 75.5%
Compound 4: the middle estimate sits 15.5 percentage points below what was measured, and the stated range covers the measured number.
By their numbers in this assay, from the lowest: compound 3; then compounds 2 and 4 (each within the scatter of the next); then compound 1.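

Cutting propanoyl to acetyl at this saturated chain carbon bound to a carbonyl carbon gives a number 8.9 percentage points higher from compound 2 to compound 4 (within the scatter) in this assay, so this methyl can go without a clear loss of maximal response. That sets this place apart from the hydroxy group, whose replacement gave a number 69 percentage points lower from compound 1 to compound 3 (beyond the scatter) in a different pair of compounds. Nothing measured here explains the result.

As far as these compounds go, whether a longer chain or an amine at this carbon would keep the response remains open. Compound 1 carries a longer ketone chain, but it differs from compound 2 in more than one place and cannot settle this.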